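The compounds below may be only part of what the source reports. "The series", "measured", "known", "first", "only" and "open" are said of these compounds alone.

Going by the values given here, in an ADME assay on microsomes from liver (Rattus norvegicus) for metabolic stability, read by LC-MS, using NADPH, with a stated time of 30 min, tested at 0.1 uM (a lower number here means that less of the compound is left, a higher number that more of the compound is left), compound 3 (`O=S(=O)(CCO)c1cccc(-c2ccc3nccc(-c4ccncc4)c3n2)c1`) gives 59%, the second highest of the three numbers measured so far. Compound 2 (`CS(=O)(=O)Nc1ccc2nccc(-c3ccncc3)c2n1`) stands higher at 94% and compound 1 (`O=S(=O)(NCC1COC1)c1cccc(-c2ccc3nccc(-c4ccncc4)c3n2)c1`) lower at 8%, both gaps lying beyond the scatter. Compound 4 (`O=S(=O)(c1cccc(-c2ccc3nccc(-c4ccncc4)c3n2)c1)N1CCC(O)CC1`) has not yet been measured. It has 4-hydroxypiperidin-1-yl in place of 2-hydroxyethyl on the sulfonyl sulfur: 4-hydroxypiperidin-1-yl in place of 2-hydroxyethyl on a sulfonyl sulfur. Among the compounds with values here, one measured step bears on this change at the same sulfur: a number 51 percentage points higher from compound 1 to compound 3 (beyond the scatter), a large step beyond the scatter, with 2-hydroxyethyl in place of ((oxetan-3-yl)methyl)amino. The entering group is also attached through nitrogen, so that step, read in reverse, points downward. The two nitrogen groups are otherwise different, so only part of its size is expected here. The expected change is a number 29 percentage points lower from compound 3 to compound 4 (beyond the scatter), a fall beyond the scatter. For compound 4 the estimated value is 30%, with an expected range from 10% to 55%.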

Compound 4, percent of the compound remaining: 11%
For compound 4 the middle estimate is 19 percentage points above the measured one, and the stated range covers the measured number.
By their numbers in this assay, from the lowest: compounds 1 and 4 (each within the scatter of the next); then compound 3; then compound 2.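

In this assay, replacing 2-hydroxyethyl with 4-hydroxypiperidin-1-yl on the sulfonyl sulfur gives a number 48 percentage points lower from compound 3 to compound 4 (beyond the scatter), so keeping a hydroxyl group in the entering group does not preserve the higher number. The two groups attached through nitrogen give no separable result, with a number 3 percentage points higher from compound 1 to compound 4 (within the scatter), and among these three compounds only the carbon-attached 2-hydroxyethyl stands apart. Nothing available here accounts for this difference.

As far as these compounds go, it remains open whether the low numbers go with attachment through nitrogen in general or only with these two groups. A small dimethylamino group on the sulfonyl sulfur and a longer carbon-attached chain such as 3-hydroxypropyl would help separate those readings.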